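A few compounds are considered here, and "the series" means these few. Any claim that something is new, unique, unknown or untested is made for them only; others in the source may bear on it.

Compound 1, `N#Cc1ccc(Cn2cc(/C=C3\NC(=O)NC3=O)c3ccccc32)cc1`: in a functional assay on A549 cells (Homo sapiens) for antiproliferative activity, read by trypan blue exclusion, with a stated time of 24 h (on this read-out higher numbers stand for weaker inhibition and lower numbers for stronger inhibition), compound 1 gives only a limit, > 40000 nM.
Compound 2, `O=C1NC(=O)/C(=C/c2cn(Cc3ccccc3)c3ccc(Br)cc23)N1`: in this assay compound 2 gives only a limit, > 40000 nM.
Compound 3, `COc1ccc2c(c1)c(/C=C1\NC(=O)NC1=O)cn2Cc1ccccc1`: in this assay compound 3 gives only a limit, > 40000 nM.

None of the three measured compounds yields a number in this assay; all of them sit at the limit of > 40000 nM in this assay, at which 3 of the 3 values shown sit. Compound 1 therefore stands at that limit and nowhere more precise, and the two other values shown are limits as well. Going by the values given here, the one step between measured compounds that differ in a single place, a step that the two limits leave unreadable from compound 2 to compound 3, is unreadable for the same reason, so its size is unknown.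

Compound 4, `Cc1ccc(Cn2cc(/C=C3\NC(=O)NC3=O)c3ccccc32)cc1`, differs from compound 1 by methyl in place of cyano on an aromatic carbon. Among the compounds with values here, no measured step bears directly on this change, and the one step that is recorded cannot be read. With every value shown at the limit, the step from compound 1 to compound 4 in this assay is expected to be none beyond the scatter, which as a step that the limit leaves unreadable from compound 1 to compound 4 is the estimate that follows. Compound 4 is thus expected to give about 80000 nM in this assay, within a range of 30000 nM to 300000 nM, and most likely to be reported only as a limit.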

Compound 4, half-maximal inhibitory concentration: 34800 nM
Beside the measured number, compound 4's estimate is 2.3-fold (0.36 log units) above it; the range from low to high includes it.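

Compound 4 is the only compound shown that gives a number rather than a limit in this assay, at 34800 nM, so methyl in place of cyano on the aromatic carbon, para to a large group, gives this position its one measured value. The change to 4-methylphenyl makes an at least 1.1-fold lower number from compound 1 to compound 4 (0.06 log units; that floor lies within the scatter); this is only a floor on the step, so the data show neither a real gain beyond the scatter nor how large the true step may be. Compound 1 itself remains a limit, and it is not alone in this: the limit of > 40000 nM in this assay, at which 3 of the 4 values shown sit.

From the compounds shown here alone, the step that stays unreadable still cannot be read, so the effect of exchanging bromo for methoxy remains unknown, and nothing shows whether either group would change the value of compound 4. Going by these compounds, it also remains open whether a measurable value depends on methyl in particular or would also appear with another group at this place, such as an ethyl group, a longer chain, an amine or a carboxylic acid.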